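The source may report more compounds than this note shows. Statements on the series, on what has been measured and on what is new or still open speak of the compounds shown alone.

Measured so far:
compound 1 `O=C(C1CCCN(Cc2ccccc2F)C1)N1CCN(c2ccccc2Cl)CC1` — 18%
compound 2 `O=C(C1CCCN(Cc2ccc(F)cc2)C1)N1CCN(c2ccccc2Cl)CC1` — 68%

In a functional assay on a cell-free system (Platelet, plasma, Homo sapiens), with stated times of 4 min and 5.5 min, tested at 0.25 uM (on this read-out higher numbers stand for a weaker effect at the one concentration tested and lower numbers for a stronger effect), compound 2 gives 68%, the higher of the two numbers; compound 1 gives 18%, and the step between them was a number 50 percentage points higher from compound 1 to compound 2 (beyond the scatter). Compound 3 `O=C(C1CCCN(Cc2ccc([N+](=O)[O-])cc2)C1)N1CCN(c2ccccc2Cl)CC1` differs from compound 2 by nitro in place of fluoro on an aromatic carbon. Among the measured compounds shown here, no measured step replaces one group with another at this place; the single step known only moved a fluoro around the ring, so it gives no direct guide. The step is therefore expected to be small, if any: a number 6 percentage points lower from compound 2 to compound 3 (within the scatter). Compound 3 is estimated at 62%, between 35% and 90%.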

Compound 3, a percentage reported as activity, at one concentration (the size of the read-out at that concentration, not a potency): 58%
Compound 3: middle estimate off by 4 percentage points, on the high side, within the range that was stated.
By their numbers in this assay, from the lowest: compound 1; then compounds 3 and 2 (each within the scatter of the next).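

In this assay, a much larger group on this aromatic carbon, with three heavy atoms and two hydrogen-bond acceptors, leaves the read-out within the scatter: a number 10 percentage points lower from compound 2 to compound 3 (within the scatter). The 4-nitrobenzyl compound also stays well apart from the 2-fluorobenzyl compound, at a number 40 percentage points higher from compound 1 to compound 3 (beyond the scatter), so neither group at this place matches the stronger effect of compound 1. Nothing measured here explains these results. As far as these compounds go, whether an amine or a carboxylic acid on this carbon would read like fluoro and nitro remains open, as does whether nitro at the ring position of the fluoro in compound 1 would keep its stronger effect.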